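The source may report more compounds than this note shows. Statements on the series, on what has been measured and on what is new or still open speak of the compounds shown alone.

Measured so far:
Compound 1 `CCN1CCC(CNC(=O)c2cc(-c3ccc(NS(=O)(=O)c4cccc(Cl)c4Cl)cc3)nc3[nH]ncc23)C1` — 109 nM
Compound 2 `Cc1n[nH]c2nc(-c3ccc(NS(=O)(=O)c4cc(Cl)ccc4F)cc3)nc(OCCC(=O)N(C)C)c12` — 438 nM

In an assay for inhibition of serine/threonine-protein kinase Sgk1 (Homo sapiens), with stated times of 30 min and 60 min, in the presence of a further agent that is not named here (on this read-out higher numbers stand for weaker inhibition and lower numbers for stronger inhibition), compound 2 gives 438 nM, the higher of the two numbers, and compound 1 gives 109 nM, a gap beyond the usual scatter. Compound 3 `Cc1n[nH]c2nc(-c3ccc(NS(=O)(=O)c4cc(Cl)ccc4F)cc3)nc(OC3CC(C)(C)N(C)C(C)(C)C3)c12` differs from compound 2 by 1,2,2,6,6-pentamethylpiperidin-4-yl in place of 2-(dimethylcarbamoyl)ethyl on an oxygen on an aromatic ring. Within the data shown here, no measured pair of compounds differs by this change alone, so the size of the step rests on expectation only. A modest step towards stronger inhibition, a 2.2-fold lower number from compound 2 to compound 3 (0.34 log units; beyond the scatter), is expected rather than none. Compound 3 is therefore estimated at 200 nM, within a range of 60 nM to 700 nM.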

Compound 3, half-maximal inhibitory concentration: 3 nM
Beside the measured number, compound 3's estimate is 67-fold (1.82 log units) above it, outside the stated range (below it).
By their numbers in this assay, from the lowest: compound 3; then compound 1; then compound 2.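

In this assay, the group on the oxygen on the aromatic ring has a large influence on inhibition: 1,2,2,6,6-pentamethylpiperidin-4-yl in place of 2-(dimethylcarbamoyl)ethyl gives a 150-fold lower number from compound 2 to compound 3 (2.16 log units; beyond the scatter). Compound 1 and compound 2 differ in more than one place, so they could not isolate this change. Nothing available bears on the reason for the size of this step.

From the compounds shown here alone, it remains open which part of the new group matters. An unmethylated piperidin-4-yl, a cyclohexyl or an open 2-(dimethylamino)ethyl chain would help separate the contributions of the methyl groups, the ring nitrogen and the ring itself.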